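Chain shortening from compound 2 to compound 3

This account rests on a few compounds, and the source may have more. Where it says the series, first, only, none or still open, it means among the compounds named here.

- compound 1 `CCCCCCCCCCOP(=O)(O)OCCSC(=S)N1CCCCCC1`: 43300 nM
- compound 2 `CCCCCCOP(=O)(O)OCCSC(=S)N1CCCCCC1`: 55000 nM
- compound 3 `CCCOP(=O)(O)OCCSC(=S)N1CCCCCC1`: not yet measured

In a functional assay on MCF7 cells (Homo sapiens) for inhibition, read by MTT assay, with stated times of 18 h and 4 h (on this read-out lower numbers stand for stronger inhibition and higher numbers for weaker inhibition), compound 2 stands at 55000 nM, within the scatter of compound 1. Compound 3 differs from it as follows: hydrogen in place of propyl on a saturated chain carbon, three bonds along the chain from an oxygen on an unsaturated carbon. Among the compounds with values here, the only measured step bearing on this is a 1.3-fold higher number from compound 1 to compound 2 (0.10 log units; within the scatter), a shortening of the same chain. As far as these compounds go, no change beyond the scatter is therefore expected in this assay, although a chain this short is untested. The expected step is a 1.1-fold higher number from compound 2 to compound 3 (0.05 log units; within the scatter). The estimate for compound 3 is 62000 nM, with an expected range of 33000 nM to 115000 nM.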

Compound 3, half-maximal inhibitory concentration: 74000 nM
Compound 3: middle estimate off by 1.2-fold (0.08 log units), on the low side, and the stated range covers the measured number.
By their numbers in this assay, from the lowest: compounds 1, 2 and 3 (each within the scatter of the next).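

In this assay the exchange of hexyl for propyl gives a 1.3-fold higher number from compound 2 to compound 3 (0.13 log units; within the scatter) and so adds a second step at this position without leaving the scatter. The whole span of the chain, read directly as a 1.7-fold higher number from compound 1 to compound 3 (0.23 log units; within the scatter), also stays within the scatter, so the three compounds show no dependence of the number on chain length. No measurement shown gives a reason for this flat result.

Open, as far as these compounds go, is whether a carboxylic acid or an amine in place of propyl, or a chain longer than that of compound 1, would move the number beyond the scatter.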